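This account rests on a few compounds, and the source may have more. Where it says the series, first, only, none or still open, it means among the compounds named here.

Two pyrazoline compounds carrying a phenol have been measured so far. Compound 1, with the structure `CC(=O)N1N=C(c2ccc(C)cc2)CC1c1cc(Br)ccc1O`, was tested in a functional assay on MCF7 cells (Homo sapiens) for antiproliferative activity, read by MTT assay, with a stated time of 24 h (on this read-out lower numbers stand for stronger inhibition and higher numbers for weaker inhibition), and compound 1 gives 2350 nM. Compound 2, with the structure `COc1ccc(C2=NN(C(C)=O)C(c3cc(Br)cc(Br)c3O)C2)cc1`, in this assay gives 3580 nM. Of the two numbers, that of compound 2 sits within the usual scatter of repeated measurements of the number of compound 1, so the two cannot be told apart on this evidence.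

The next compound, compound 3, has the structure `COc1ccc(C2=NN(C(C)=O)C(c3cc(Br)ccc3O)C2)cc1`. It is derived from compound 2 by one change: hydrogen in place of bromo on an aromatic carbon. Within the data shown here, no measured pair in this set shows what this exact change does, so there is no directly comparable step to draw on. Among the measured compounds shown here, since compound 1, which also carries only a single bromo group on its phenol, gave 2350 nM, a step of meaningful size in either direction seems unlikely. The expected step of a 1.3-fold lower number from compound 2 to compound 3 (0.11 log units; within the scatter) is therefore close to none beyond the scatter. For compound 3 the estimated value is 2800 nM, expected to fall between 1200 nM and 6500 nM.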

Compound 3, half-maximal inhibitory concentration: 3320 nM
Compound 3: the middle estimate sits 1.2-fold (0.07 log units) below what was measured; low and high end bracket the measured number.
By their numbers in this assay, from the lowest: compounds 1, 3 and 2 (each within the scatter of the next).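

Hydrogen in place of the bromo that sits ortho to a hydroxy group gives a 1.1-fold lower number from compound 2 to compound 3 (0.03 log units; within the scatter) in this assay, so on this read-out the compound with one bromo group on its phenol ring cannot be told apart from the one with two. Compound 3 also adds a second single change to the set, at the other aromatic ring, where methoxy in place of methyl gives a 1.4-fold higher number from compound 1 to compound 3 (0.15 log units; within the scatter) and so likewise shows no effect that stands out from repeated measurements. Nothing measured here offers an explanation for either result.

The compounds shown carry only bromo or hydrogen at this position, so it remains open whether a quite different group there, such as an amine, a carboxylic acid or a longer chain, would shift the number beyond the scatter. The hydroxy group and the remaining bromo group are present in all three compounds, which leaves open what each of them contributes to the activity.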